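The compounds below may be only part of what the source reports. "The series", "measured", "known", "first", "only" and "open" are said of these compounds alone.

Compound 3 `COc1ccc(-c2cc(/C=C/C(=O)c3ccc(N)cc3)[nH]n2)cc1OC` and compound 1 `COc1cc(-c2cc(/C=C/C(=O)c3ccc(N)cc3)[nH]n2)cc(OC)c1OC` share one core, while compound 2 `COc1ccc(C(=O)/C=C/c2cc(-c3cc(OC)c(OC)c(OC)c3)n[nH]2)cc1OC` and compound 4 `COc1cc(C(=O)/C=C/c2cc(-c3cc(OC)c(OC)c(OC)c3)n[nH]2)cc(OC)c1OC` share another; how the two cores differ is not broken down here. In a functional assay on HOP-92 cells (Homo sapiens) for inhibition, read by sulforhodamine B assay, with a stated time of 48 h (a higher number here means a weaker inhibitor of growth, a lower number a stronger inhibitor of growth), compound 3 gives 1490 nM and compound 1 gives 3680 nM, a change of methoxy in place of hydrogen on an aromatic carbon that brought a 2.5-fold higher number from compound 3 to compound 1 (0.39 log units; beyond the scatter). In this assay compound 2 gives "not determined" (no result reported), so no result is reported for it. Compound 4 carries the same change against compound 2, (methoxy in place of hydrogen on an aromatic carbon), the place being described in the same words, so the same kind of weakening step would be expected; yet with compound 2 unmeasured there is no starting point, and the expectation for compound 4 rests on compound 1 alone, whose value is 3680 nM. Compound 4 is therefore estimated at 3500 nM in this assay, expected between 800 nM and 16000 nM.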

Compound 4, concentration for 50% growth inhibition: 860 nM
For compound 4 the middle estimate is 4.1-fold (0.61 log units) above the measured one, and the stated range covers the measured number.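

No new step can be read, as compound 2 has no number to set against compound 4. No measured property here explains the result. On these data alone, whether methoxy in place of hydrogen weakens growth inhibition on the core of compound 4 stays open.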